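This account rests on a few compounds, and the source may have more. Where it says the series, first, only, none or still open, it means among the compounds named here.

Three compounds share one core and differ only in the group attached through an oxygen on a saturated carbon. In a functional assay on HEK293 cells for agonist activity at G-protein coupled receptor 39 (Homo sapiens), read by scintillation proximity assay and inositol phosphate accumulation, with a stated time of 75 min (a higher number here means that more compound is needed for the effect, a lower number that less compound is needed), compound 1 `CCCCCCCCOC1CC(=O)Nc2c1c(C)nn2-c1ncnc2nc[nH]c12` gives 388 nM, compound 2 `Cc1nn(-c2ncnc3nc[nH]c23)c2c1C(OCc1ccccc1C#N)CC(=O)N2` gives 127 nM, and compound 3 `Cc1nn(-c2ncnc3nc[nH]c23)c2c1C(OCCn1nccc1C)CC(=O)N2` gives 1620 nM. Compound 3 therefore stands highest of the three: the step from compound 1 reads a 4.2-fold higher number from compound 1 to compound 3 (0.62 log units; beyond the scatter), and the step from compound 2 reads a 13-fold higher number from compound 2 to compound 3 (1.11 log units; beyond the scatter).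

Compound 4 `Cc1nn(-c2ncnc3nc[nH]c23)c2c1C(OCc1cc(F)cc3c1OCOC3)CC(=O)N2` is the next step from compound 3: a group of 11 heavy atoms (8 carbon, 2 oxygen, 1 fluorine; one six-membered non-aromatic ring with 2 hetero atoms, one six-membered aromatic ring of carbon only) in place of a group of 7 heavy atoms (5 carbon, 2 nitrogen; one five-membered aromatic ring with 2 hetero atoms), on a saturated chain carbon bound to an oxygen on a saturated carbon. The most relevant measured step is a 13-fold higher number from compound 2 to compound 3 (1.11 log units; beyond the scatter), where an aromatic ring bound directly to the chain carbon was exchanged for the (5-methyl-1H-pyrazol-1-yl)methyl group; compound 4 returns an aromatic ring to that position, so a large step toward a lower number is expected, roughly an 8.1-fold lower number from compound 3 to compound 4 (0.91 log units; beyond the scatter). The smaller step of a 3.1-fold lower number from compound 1 to compound 2 (0.49 log units; beyond the scatter) also points in that direction. For compound 4 in this assay the expected value is 200 nM, with a likely range from 60 nM to 700 nM.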

Compound 4, half-maximal effective concentration: 30 nM
Compound 4: the middle estimate sits 6.7-fold (0.82 log units) above what was measured, outside the stated range (below it).
By their numbers in this assay, from the lowest: compound 4; then compound 2; then compound 1; then compound 3.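

Compound 4 stands lowest of the four in this assay, well clear of the pyrazole compound (a 54-fold lower number from compound 3 to compound 4 (1.73 log units; beyond the scatter)) and of the open-chain compound (a 13-fold lower number from compound 1 to compound 4 (1.11 log units; beyond the scatter)). The earlier compounds shown here left 2-cyanophenyl as the best group at this place, but the number can fall further on the same saturated chain carbon when a group with a six-membered aromatic ring of carbon only also carries fluorine and a second, non-aromatic ring (a 4.2-fold lower number from compound 2 to compound 4 (0.63 log units; beyond the scatter)). Nothing measured here gives a reason for this drop.

The entering group differs from 2-cyanophenyl in several features at once, so these compounds cannot say how much the fluorine or the non-aromatic ring contributes alone. On these data alone, whether an amine or a carboxylic acid on the aromatic ring would keep the number this low also remains open.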